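Acyl chain extension on the thiophene amide series

A few compounds are considered here, and "the series" means these few. Any claim that something is new, unique, unknown or untested is made for them only; others in the source may bear on it.

Of the compounds shown here, three have numbers so far in an assay on HEK293 cells for inhibition of Indoleamine 2,3-dioxygenase 1 (Homo sapiens), tested at 10 uM; on this read-out higher numbers stand for more inhibition at the one concentration tested (going by the name of the read-out) and lower numbers for less inhibition. Compound 1 `CC(=O)N1CCc2cc(CNC(=O)c3cccs3)ccc21` gives 72% in this assay, the lowest of the three numbers. Compound 3 `CCC(=O)N1CCc2cc(CNC(=O)c3ccccc3)ccc21` gives 87% in this assay, and compound 2 `CC(C)C(=O)N1CCc2cc(CNC(=O)c3ccc(F)cc3)ccc21` gives 88% in this assay; both stand beyond the scatter above compound 1, with compound 3 the nearer of the two. Within the data shown here, compounds 2 and 3 differ from compound 1 in more than one place, so no single step between measured compounds is available.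

Compound 4 `CC(C)CC(=O)N1CCc2cc(CNC(=O)c3cccs3)ccc21` keeps the thiophene amide of compound 1 and changes only the acyl group: isopropyl in place of hydrogen on a saturated chain carbon bound to a carbonyl carbon. The two higher numbers of compounds 2 and 3 both carry larger acyl groups than compound 1, which is the only ground for direction here. The step from compound 1 to compound 4 in this assay is expected to be a small to moderate rise, a number 8 percentage points higher from compound 1 to compound 4 (within the scatter), but could also sit within the scatter. Compound 4 is therefore estimated at 80% in this assay. The expected range for compound 4 runs from 65% to 92%.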

Compound 4, a percentage reported as inhibition, at one concentration (the size of the read-out at that concentration, not a potency): 100%
The estimate for compound 4 lay 20 percentage points below the measured number; measured number outside the range, above it.
By their numbers in this assay, from the lowest: compound 1; then compounds 3 and 2 (each within the scatter of the next); then compound 4.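

Among these compounds, on the thiophene amide, the acyl group gives the first single-place comparison in this assay: isopropyl in place of hydrogen on a saturated chain carbon bound to a carbonyl carbon gives a number 28 percentage points higher from compound 1 to compound 4 (beyond the scatter), a step beyond the scatter. With the rest of compound 1 held fixed, this position therefore accepts isobutylcarbonyl in place of acetyl, and the change raises inhibition at the one concentration tested, with compound 4 at 100% in this read-out. No measurement at hand bears on the reason for this rise.

Going by these compounds, it remains open whether a longer chain, a cyclohexyl group or an amine at this acyl position would keep the number. Also open, on these data alone, is whether isobutylcarbonyl has a similar effect on the amides of compounds 2 and 3.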